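Series at the assay limit: the step to compound 4

A few compounds are considered here, and "the series" means these few. Any claim that something is new, unique, unknown or untested is made for them only; others in the source may bear on it.

Of the compounds shown here, three have been read in a functional assay on NCI-H460 cells (Homo sapiens); a lower number here means a stronger inhibitor, a higher number a weaker inhibitor. Compound 1 `COc1cc(NC(C)CCCNC(=O)NCCO)c2ncccc2c1` gives > 100000 nM, which is a limit and not a number. Compound 2 `COc1cc(NC(C)CCCNC(=O)NCCCO)c2ncccc2c1` gives > 100000 nM, again a limit. Compound 3 `COc1cc(NC(C)CCCNC(=O)NC(CO)(CO)CO)c2ncccc2c1` gives > 100000 nM, also a limit. The whole record so far is the limit of > 100000 nM in this assay, at which 3 of the 3 values shown sit, and compound 3 stands there with the other two.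

Compound 4 `COc1cc(NC(C)CCCNC(=O)NO)c2ncccc2c1` differs from compound 3 at one place: hydroxy in place of 2-hydroxy-1,1-bis(hydroxymethyl)ethyl on an amide-type nitrogen.

The three measured steps bear on this change: a step that the two limits leave unreadable from compound 1 to compound 2, a step that the two limits leave unreadable from compound 1 to compound 3 and a step that the two limits leave unreadable from compound 2 to compound 3. Both ends of each are limits, and none has a readable size to carry over. With the limit of > 100000 nM in this assay, at which 3 of the 3 values shown sit, compound 4 is expected to remain a weak inhibitor in this assay. Any number read for compound 4 would lie on the stronger side of the limit held by compound 3, so the expected direction is towards stronger inhibition, although the reading may well stay at the limit. The expected step is an at least 2.5-fold lower number from compound 3 to compound 4 (0.39 log units; beyond the scatter). For compound 4 the estimated value is 40000 nM, with an expected range of 8000 nM to 100000 nM.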

Compound 4, half-maximal inhibitory concentration: > 100000 nM
Compound 4 ended at the assay's limit; the forecaster's own chance of this, stated with the estimate: 40%; middle value at least 2.5-fold (0.39 log units) away from the limit.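

In this assay no step from compound 1, compound 2 or compound 3 to compound 4 can be read, as both ends of each are limits and not numbers: the limit of > 100000 nM in this assay, at which 4 of the 4 values shown sit.

The compounds shown leave open how far past that limit each one lies, and whether hydroxy, 2-hydroxyethyl, 3-hydroxypropyl and 2-hydroxy-1,1-bis(hydroxymethyl)ethyl on the amide-type nitrogen differ at all in this assay when read as numbers.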